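Two Single Changes on One Core, Then Both Together

This account rests on a few compounds, and the source may have more. Where it says the series, first, only, none or still open, it means among the compounds named here.

Compound 1 `CC1=NN(c2ccc(Br)cc2)C(=O)C12C=CC(=O)C=C2c1ccccc1` is the reference point of this set. In a functional assay on A549 cells (Homo sapiens) for antiproliferative activity, read by CCK-8 assay, with a stated time of 72 h (on this read-out lower numbers stand for stronger inhibition and higher numbers for weaker inhibition), compound 1 gives > 100000 nM, which is a limit of the assay and not a number (the limit of > 100000 nM in this assay, at which 1 of the 3 values shown sits). Two compounds differ from it in one place each. Compound 2 `CC1=NN(c2cccc(Cl)c2)C(=O)C12C=CC(=O)C=C2c1ccccc1` carries 3-chlorophenyl in place of 4-bromophenyl on an amide-type nitrogen in a ring, and in this assay compound 2 gives 18800 nM; the step is an at least 5.3-fold lower number from compound 1 to compound 2 (0.72 log units; beyond the scatter). Compound 3 `CC1=NN(c2ccc(Br)cc2)C(=O)C12C=CC(=O)C=C2c1ccc(C)cc1` carries methyl in place of hydrogen on an aromatic carbon, and in this assay compound 3 gives 27400 nM; the step is an at least 3.6-fold lower number from compound 1 to compound 3 (0.56 log units; beyond the scatter). The values of compound 2 and compound 3 lie within the scatter of each other.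

Compound 4 `CC1=NN(c2cccc(Cl)c2)C(=O)C12C=CC(=O)C=C2c1ccc(C)cc1` joins both changes on the core of compound 3. Among the measured compounds shown here, its difference from compound 3 is 3-chlorophenyl in place of 4-bromophenyl on an amide-type nitrogen in a ring, the same change at the same place, word for word, as the one between compound 1 and compound 2. That earlier step began from a limit, so only its lower bound is known. The expected step is a 4.6-fold lower number from compound 3 to compound 4 (0.66 log units; beyond the scatter), resting on the observation that an at least 5.3-fold lower number from compound 1 to compound 2 (0.72 log units; beyond the scatter). In this assay compound 4 is expected to give about 6000 nM, with a likely range from 2000 nM to 25000 nM.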

Compound 4, half-maximal inhibitory concentration: 9050 nM
Compound 4: middle estimate off by 1.5-fold (0.18 log units), on the low side; low and high end bracket the measured number.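

In this assay, 3-chlorophenyl in place of 4-bromophenyl still lowers the number on the core carrying the methyl group, giving a 3.0-fold lower number from compound 3 to compound 4 (0.48 log units; beyond the scatter), and the methyl group still lowers it on the core carrying 3-chlorophenyl, giving a 2.1-fold lower number from compound 2 to compound 4 (0.32 log units; beyond the scatter). The direction of the first change thus holds on both cores, but this does not show that its size carries over unchanged: the same change on two cores in this assay, an at least 5.3-fold lower number (0.72 log units; beyond the scatter) from compound 1 to compound 2 and a 3.0-fold lower number (0.48 log units; beyond the scatter) from compound 3 to compound 4; the limit leaves it open whether they differ The same holds for the methyl group, whose direction repeats on the second core while the comparison of sizes stays unsettled: the same change on two cores in this assay, an at least 3.6-fold lower number (0.56 log units; beyond the scatter) from compound 1 to compound 3 and a 2.1-fold lower number (0.32 log units; beyond the scatter) from compound 2 to compound 4; the limit leaves it open whether they differ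

The swap from 4-bromophenyl to 3-chlorophenyl alters the halogen and its place on the ring together, so the compounds shown leave open which of the two goes with the lower numbers; 4-chlorophenyl and 3-bromophenyl would separate them. As far as these compounds go, it also remains open whether an amine or a carboxylic acid in the place of the methyl group would combine with 3-chlorophenyl in the same direction.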